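The compounds below may be only part of what the source reports. "The series", "measured", "known", "first", "only" and "open" are said of these compounds alone.

Compound 1 `O=C(Nc1ccccc1)c1cc(Oc2ccc(/C=C/c3ccccn3)cc2)ccn1` is the point of reference. In a functional assay on HepG2 cells (Homo sapiens) for antiproliferative activity, read by CCK-8 assay, with a stated time of 48 h (on this read-out higher numbers stand for weaker inhibition and lower numbers for stronger inhibition), compound 1 gives 30200 nM. Compound 2 `CC(C)NC(=O)c1cc(Oc2ccc(/C=C/c3ccccn3)cc2)ccn1` carries isopropyl in place of phenyl on the amide-type nitrogen. In this assay compound 2 gives only a limit, > 100000 nM, so its true number is not known. Within the data shown here, the step of an at least 3.3-fold higher number from compound 1 to compound 2 (0.51 log units; beyond the scatter) is the only measured step in the set, and its size is open-ended because of the limit of > 100000 nM in this assay, at which 1 of the 2 values shown sits.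

Compound 3 `O=C(NC1CC1)c1cc(Oc2ccc(/C=C/c3ccccn3)cc2)ccn1` differs from compound 2 by cyclopropyl in place of isopropyl on an amide-type nitrogen. Among the measured compounds shown here, no measured step concerns this particular exchange. For the measured compounds named here, the one step available, an at least 3.3-fold higher number from compound 1 to compound 2 (0.51 log units; beyond the scatter), went from phenyl to a small alkyl group and moved toward weaker inhibition, ending at the limit. Going from one small alkyl group to another is a smaller change than that, so compound 3 is expected to stay near compound 2, with no step beyond the scatter. For compound 3 the expected step is a number no higher from compound 2 to compound 3 (the limit leaves the size open). In this assay compound 3 is estimated at 100000 nM, within a range from 30000 nM to 300000 nM. A limit rather than a number is again thought likely for compound 3.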

Compound 3, half-maximal inhibitory concentration: 31000 nM
Compound 3: the middle estimate sits 3.2-fold (0.51 log units) above what was measured; low and high end bracket the measured number.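

In this assay, the exchange of isopropyl for cyclopropyl on the amide-type nitrogen proves to be no neutral swap, although both groups carry 3 heavy atoms: the step reads an at least 3.2-fold lower number from compound 2 to compound 3 (0.50 log units; beyond the scatter). The second step, a 1.0-fold higher number from compound 1 to compound 3 (0.01 log units; within the scatter), shows that among these three compounds phenyl is not needed on this nitrogen to reach the level of compound 1, and that a group without an aromatic ring can stand level with it, so the loss seen with isopropyl does not extend to every small alkyl group. The first of these steps has no upper end because the value of compound 2 is a limit and not a number: the limit of > 100000 nM in this assay, at which 1 of the 3 values shown sits.

From the compounds shown here alone, how cyclobutyl, benzyl, a longer chain such as n-butyl or a chain ending in an amine would stand on this nitrogen remains open, as does whether any group here can bring the number well below those of compound 1 and compound 3. Also open, going by these compounds, is what happens with a methyl group in place of the amide hydrogen, and whether the difference between cyclopropyl and isopropyl holds on any other core.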